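Pyridyl isomer change in a histamine H1 antagonist series

The source may hold more compounds than are shown below. What is called first, only, known or untested is meant among the compounds shown, and "the series" means these compounds.

Measured so far:
compound 1, `N=C(NCCCc1c[nH]cn1)NCCCC(c1ccc(F)cc1)c1ccccn1`, with 46.8 nM
compound 2, `N=C(NCCCc1c[nH]cn1)NCCC(c1ccc(F)cc1)c1cccnc1`, with 195 nM

In a functional assay on ileum for antagonist activity at histamine H1 receptor (Cavia porcellus) (a higher number here means weaker binding, a lower number tighter binding), compound 2 gives 195 nM, the highest of the two numbers; compound 1 gives 46.8 nM, a lower number beyond the scatter. Compound 3, `N=C(NCCCc1c[nH]cn1)NCCC(c1ccncc1)c1ccc(F)cc1`, differs from compound 2 in one place: pyridin-4-yl in place of pyridin-3-yl on a saturated chain carbon bound to an aromatic carbon and a saturated chain carbon. Within the data shown here, no measured pair in this set separates two such isomers, so nothing here shows how large a step to expect, and the change is expected to stay within the scatter, in no set direction. Compound 3 is therefore estimated at 200 nM, between 60 nM and 650 nM, a step of a 1.0-fold higher number from compound 2 to compound 3 (0.01 log units; within the scatter) that is expected to be small.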

Compound 3, dissociation constant: 37.2 nM
For compound 3 the middle estimate is 5.4-fold (0.73 log units) above the measured one; the whole stated range lies above it.
By their numbers in this assay, from the lowest: compounds 3 and 1 (each within the scatter of the next); then compound 2.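

In this assay, pyridin-4-yl in place of pyridin-3-yl on a saturated chain carbon bound to an aromatic carbon and a saturated chain carbon gives a 5.2-fold lower number from compound 2 to compound 3 (0.72 log units; beyond the scatter) and so shows that these two isomers are not interchangeable at this position, although they have the same atoms. Nothing available explains the step. The compounds shown leave open how pyridin-2-yl or an unsubstituted phenyl would compare at this position on the same chain. They also leave open whether the step between the two isomers would recur on the longer chain of compound 1.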